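Hydroxymethyl to 1-Hydroxyethyl: One Methyl Added

A few compounds are considered here, and "the series" means these few. Any claim that something is new, unique, unknown or untested is made for them only; others in the source may bear on it.

Compound 1, `O=C(CN(c1ncnc2c1ncn2C1CCCCO1)C1CC1)N[C@@H](CO)C(=O)OCc1ccccc1`, gives 18.3% in a functional assay on the whole organism (Tail, strain ICR) with Mus musculus as the target, in the tail flick test, with a stated time of 150 min, at a dose of 25 umol/kg by the oral route (on this read-out higher numbers stand for a stronger effect at the one dose given and lower numbers for a weaker effect), the highest of the three numbers shown, though compound 2 lies within the scatter of it. Compound 2, `NC(=O)CC[C@H](NC(=O)CN(c1nc(Cl)nc2[nH]cnc12)C1CC1)C(=O)O`, gives 11.4%, and compound 3, `CC[C@H](C)[C@H](NC(=O)CN(c1nc(Cl)nc2[nH]cnc12)C1CC1)C(=O)O`, gives 6.71%, a number beyond the scatter below compound 1. Within the data shown here, the only step measured between single-change neighbours, a number 4.7 percentage points lower from compound 2 to compound 3 (within the scatter), concerns sec-butyl in place of 2-carbamoylethyl and stays within the scatter. Compound 4, `C[C@@H](O)[C@H](NC(=O)CN(c1ncnc2c1ncn2C1CCCCO1)C1CC1)C(=O)OCc1ccccc1`, differs from compound 1 by methyl in place of hydrogen on a saturated chain carbon bound to an oxygen on a saturated carbon and a saturated chain carbon. Among the measured compounds shown here, no measured step touches this position, and the one step available was small, so no step beyond the scatter is expected: a number 0.3 percentage points lower from compound 1 to compound 4 (within the scatter). Compound 4 is therefore estimated at 18%, between 7% and 30%.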

Compound 4, a percentage reported as activity, at one dose (the size of the read-out at that dose, not a potency): 6.53%
The estimate for compound 4 lay 11.5 percentage points above the measured number; measured number below the stated range.
By their numbers in this assay, from the lowest: compounds 4, 3, 2 and 1 (each within the scatter of the next, the first and the last beyond it).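

Methyl in place of hydrogen on a saturated chain carbon bound to an oxygen on a saturated carbon and a saturated chain carbon gives, in this assay, a number 11.8 percentage points lower from compound 1 to compound 4 (beyond the scatter) and so is a modest step beyond the scatter. Among these compounds, this position, which no earlier step touched, is therefore not silent on this read-out at the one dose given, even for a change of one carbon. Nothing available explains the loss.

As far as these compounds go, whether an ethyl group or a longer chain at this carbon, or an amine in place of the hydroxyl, would give a similar loss stays open. So does whether the same methyl would have a similar effect on the core of compound 2.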